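Lengthening the nitroimidazole chain of compound 2

The source may report more compounds than this note shows. Statements on the series, on what has been measured and on what is new or still open speak of the compounds shown alone.

Measured so far in a functional assay on A549 cells (Homo sapiens) for inhibition, read by sulforhodamine B assay, with a stated time of 72 h; a higher number here means a weaker inhibitor, a lower number a stronger inhibitor:
- compound 1 `COc1cc2c(Nc3ccc(F)c(Cl)c3)ncnc2cc1OCCCn1ccnc1[N+](=O)[O-]` gives 5910 nM
- compound 2 `COc1cc2c(Nc3ccc(OCc4cccc(F)c4)c(Cl)c3)ncnc2cc1OCCCn1ccnc1[N+](=O)[O-]` gives 3970 nM

Compound 2 stands within the scatter of compound 1, so these two numbers give no ranking. Compound 3 `COc1cc2c(Nc3ccc(OCc4cccc(F)c4)c(Cl)c3)ncnc2cc1OCCCCCCn1ccnc1[N+](=O)[O-]` carries 3-(2-nitro-1H-imidazol-1-yl)propyl in place of 2-nitro-1H-imidazol-1-yl on a saturated chain carbon, three bonds along the chain from an oxygen on an aromatic ring. The counted difference is 3-(2-nitro-1H-imidazol-1-yl)propyl in place of 2-nitro-1H-imidazol-1-yl on a saturated chain carbon, three bonds along the chain from an oxygen on an aromatic ring as computed from the two structures.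

Among the compounds with values here, the only measured step, a 1.5-fold lower number from compound 1 to compound 2 (0.17 log units; within the scatter) and thus within the scatter, is (3-fluorobenzyl)oxy in place of fluoro on an aromatic carbon. Within the data shown here, it lies at another place, and no measured pair varies this chain. It therefore gives no direction, and only weak support for expecting no step beyond the scatter in this assay here. The estimate is anchored on compound 2 at 3970 nM as the nearest measured structure. The expected step, a 1.2-fold lower number from compound 2 to compound 3 (0.08 log units; within the scatter) as estimated, stays within the scatter. Compound 3 is expected at 3300 nM with an estimated range of 1200 nM to 8500 nM on this thin evidence.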

Compound 3, half-maximal inhibitory concentration: > 50000 nM
Compound 3 ended at the assay's limit; the forecaster's own chance of this, stated with the estimate: 5%; at least 15-fold (1.18 log units) between middle value and limit.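

Within the data shown here, the position on a saturated chain carbon, three bonds along the chain from an oxygen on an aromatic ring, is the first place where a change can be read in this assay; the only earlier step, a 1.5-fold lower number from compound 1 to compound 2 (0.17 log units; within the scatter), lay at another place and gave no ranking. Here, 3-(2-nitro-1H-imidazol-1-yl)propyl in place of 2-nitro-1H-imidazol-1-yl gives an at least 12-fold higher number from compound 2 to compound 3 (1.10 log units; beyond the scatter), and the entering group differs from the leaving one only by the added propyl chain, with the nitroimidazole itself kept. Compound 3 gives > 50000 nM, which is a limit of the assay and not a number, so this step fixes a direction and a minimum size only: the limit of > 50000 nM in this assay, at which 1 of the 3 values shown sits.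

On these data alone, with only these two chain lengths in view, it stays open whether a chain of intermediate length keeps the level of compound 2 or whether the loss is already complete there. As far as these compounds go, it also stays open whether the long chain is tolerated with a different end group, such as an amine or a carboxylic acid in place of the 2-nitro-1H-imidazol-1-yl.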